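Cyclohexylamino in place of piperidin-1-yl

The source may hold more compounds than are shown below. What is called first, only, known or untested is meant among the compounds shown, and "the series" means these compounds.

- compound 1 `CC(C)=CCC/C(C)=C/CC/C(C)=C/CSC[C@H](NC(=O)CCCCCN1CCN(C)CC1)C(=O)NC1CC1` gives 10400 nM
- compound 2 `CC(C)=CCC/C(C)=C/CC/C(C)=C/CSC[C@H](NC(=O)CCCCCN1CCN(C)CC1)C(=O)N1CCCC1` gives 6000 nM
- compound 3 `CC(C)=CCC/C(C)=C/CC/C(C)=C/CSC[C@H](NC(=O)CCCCCN1CCN(C)CC1)C(=O)N1CCCCC1` gives 14300 nM

In a functional assay on MIA PaCa-2 cells (Homo sapiens) for cytotoxicity, read by fluorescence, with a stated time of 48 h (on this read-out lower numbers stand for an effect already at smaller amounts and higher numbers for an effect only at larger amounts of compound), compound 3 gives 14300 nM, which places it at the upper end of the three numbers. It lies within the scatter of compound 1, while the gap to compound 2 goes beyond it: a 2.4-fold higher number from compound 2 to compound 3 (0.38 log units; beyond the scatter).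

The unmeasured compound 4 `CC(C)=CCC/C(C)=C/CC/C(C)=C/CSC[C@H](NC(=O)CCCCCN1CCN(C)CC1)C(=O)NC1CCCCC1` carries cyclohexylamino in place of piperidin-1-yl on a carbonyl carbon. All three measured steps concern this same place. Like compound 4, compound 1 keeps the amide hydrogen and gives 10400 nM, which makes it the closest guide. Its link to the piperidin-1-yl compound is small: a 1.4-fold higher number from compound 1 to compound 3 (0.14 log units; within the scatter). The exchange for pyrrolidin-1-yl is also small: a 1.7-fold lower number from compound 1 to compound 2 (0.24 log units; within the scatter). The largest change seen here is only modest, at a 2.4-fold higher number from compound 2 to compound 3 (0.38 log units; beyond the scatter).

A large shift is therefore not expected, and the number should move, if at all, slightly towards that of compound 1. The expected change is a 1.4-fold lower number from compound 3 to compound 4 (0.16 log units; within the scatter), which would stay within the scatter. For compound 4 the estimated value in this assay is 10000 nM, with an expected range of 5000 nM to 20000 nM.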

Compound 4, half-maximal effective concentration: 5900 nM
Estimate against measurement, compound 4: 1.7-fold (0.23 log units) above; the measured number falls inside the stated range.
By their numbers in this assay, from the lowest: compounds 4, 2, 1 and 3 (each within the scatter of the next, the first and the last beyond it).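

In this assay, the exchange of piperidin-1-yl for cyclohexylamino on this carbonyl carbon gives a 2.4-fold lower number from compound 3 to compound 4 (0.38 log units; beyond the scatter), so a six-membered ring at this place does not fix the number: the ring of carbon only, with its amide hydrogen, and the ring with one hetero atom lie beyond the scatter of each other. Going by these compounds alone, this step is of the same size as a 2.4-fold higher number from compound 2 to compound 3 (0.38 log units; beyond the scatter), the only step beyond the scatter among the earlier compounds, and it shows that compound 3 is separated from compound 4 as well as from compound 2. The other two new steps stay within the scatter, a 1.0-fold lower number from compound 2 to compound 4 (0.01 log units; within the scatter) and a 1.8-fold lower number from compound 1 to compound 4 (0.25 log units; within the scatter), yet the amide hydrogen does not sort the series, since compound 2 lacks it and still stands within the scatter of compound 4, while compound 3 lacks it and stands within the scatter of compound 1.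

On these data alone, it remains open whether an open-chain diethylamino group or a morpholin-4-yl ring on this carbonyl carbon would stay within the span of these four numbers, and how a change in the shared core would act on them. The compounds shown come with no measurement that could explain the difference between compound 3 and compound 4.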